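The compounds below may be only part of what the source reports. "The series", "measured", "known", "first", "only" and "open" are said of these compounds alone.

For the measured compounds named here, in a functional assay on FM3A cells (Mus musculus) for cytotoxicity, read by cell counting, with a stated time of 2 days (on this read-out higher numbers stand for weaker inhibition and lower numbers for stronger inhibition), compound 1 `C=C(Br)C(=O)Nc1cccc(/C=C2\SC(=O)N(Cc3ccc(C(C)(C)C)cc3)C2=O)c1` gives 5200 nM, while compound 2 `C=C(Br)C(=O)Nc1cccc(/C=C2\SC(=O)N(Cc3ccc(C(F)(F)F)cc3)C2=O)c1` gives 870 nM, the lowest of the two numbers measured so far. Going by the values given here, the only measured step, a 6.0-fold lower number from compound 1 to compound 2 (0.78 log units; beyond the scatter), changes the same benzyl group that changes again here. Compound 3 `C=C(Br)C(=O)Nc1cccc(/C=C2\SC(=O)N(Cc3cccc(F)c3)C2=O)c1` differs from compound 2 by 3-fluorophenyl in place of 4-(trifluoromethyl)phenyl on a saturated chain carbon bound to an amide-type nitrogen in a ring. Among the compounds with values here, no measured step covers this kind of change, so only a modest shift toward a higher number is expected, a 1.7-fold higher number from compound 2 to compound 3 (0.24 log units; within the scatter), with wide uncertainty. Compound 3 is therefore estimated to give 1500 nM in this assay, within a range from 500 nM to 5000 nM.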

Compound 3, half-maximal inhibitory concentration: 690 nM
Estimate against measurement, compound 3: 2.2-fold (0.34 log units) above, and the stated range covers the measured number.
By their numbers in this assay, from the lowest: compounds 3 and 2 (each within the scatter of the next); then compound 1.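

At this position on the saturated chain carbon, 3-fluorophenyl and 4-(trifluoromethyl)phenyl cannot be told apart in this assay, despite their different heavy-atom counts: the step is a 1.3-fold lower number from compound 2 to compound 3 (0.10 log units; within the scatter). The second fluorine-bearing group also stands clear of 4-(tert-butyl)phenyl, with a 7.5-fold lower number from compound 1 to compound 3 (0.88 log units; beyond the scatter), so compound 1 alone stands apart among these three. No measurement here explains this behaviour. As far as these compounds go, it remains open how an unsubstituted phenyl or a methoxyphenyl would read at this position, and so whether fluorine itself matters.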